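This account rests on a few compounds, and the source may have more. Where it says the series, first, only, none or still open, it means among the compounds named here.

Working notes on the series in a functional assay on C8166 cells (Homo sapiens) for cytotoxicity, read by MTT assay; on this read-out higher numbers stand for lower toxicity in this test and lower numbers for higher toxicity in this test. Compound 1 `Cc1ccc(C(=O)Nc2cc(Cl)ccc2OCC(=O)Nc2ccc(S(N)(=O)=O)cc2C)cc1` gives 54200 nM and compound 2 `Cc1ccc(C(=O)Nc2cc(Cl)ccc2OCC(=O)Nc2ccc(S(N)(=O)=O)cc2C)c(C)c1` gives 47600 nM, so compound 2 stands level with compound 1 within the scatter. Among the compounds with values here, the only measured step, a 1.1-fold lower number from compound 1 to compound 2 (0.06 log units; within the scatter), is methyl in place of hydrogen on an aromatic carbon of the group now to be replaced.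

The next structure is compound 3 `Cc1cc(S(N)(=O)=O)ccc1NC(=O)COc1ccc(Cl)cc1NC(=O)c1ccc(Cl)cc1Cl`, with 2,4-dichlorophenyl in place of 2,4-dimethylphenyl on a carbonyl carbon. No chlorine on this group has been measured yet, so the guidance is thin. The small size of a 1.1-fold lower number from compound 1 to compound 2 (0.06 log units; within the scatter) gives no reason to expect a large move, and no firm direction can be drawn from it. The expected change is a 1.2-fold lower number from compound 2 to compound 3 (0.08 log units; within the scatter), with no shift beyond the scatter anticipated. For compound 3 the estimated value is 40000 nM, with an expected range of 15000 nM to 90000 nM.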

Compound 3, half-maximal cytotoxic concentration: 61100 nM
The estimate for compound 3 lay 1.5-fold (0.18 log units) below the measured number; the range from low to high includes it.
By their numbers in this assay, from the lowest: compounds 2, 1 and 3 (each within the scatter of the next).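

In this assay, 2,4-dichlorophenyl in place of 2,4-dimethylphenyl on a carbonyl carbon gives a 1.3-fold higher number from compound 2 to compound 3 (0.11 log units; within the scatter), so exchanging both methyl groups for chlorine, at an unchanged heavy-atom count, does not move the read-out beyond the scatter. 2,4-dichlorophenyl in place of 4-methylphenyl gives a 1.1-fold higher number from compound 1 to compound 3 (0.05 log units; within the scatter), which is also within the scatter, so the three groups on this carbonyl carbon now stand level with chlorine as well as methyl present. No measurement at hand bears on why the read-out stays level at this position.

Still open, going by these compounds, is whether an amine or a carboxylic acid on the phenyl ring of this group would shift the number beyond the scatter. Equally open, on these data alone, is whether a change outside this group, such as a longer chain on the shared core, would do so.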